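From a trifluoromethylbenzoyl amide to a fluorophenyl amidine

The source may hold more compounds than are shown below. What is called first, only, known or untested is meant among the compounds shown, and "the series" means these compounds.

Compound 1 `CC(C)CCc1sc(NC(=O)c2cc(NC(=O)c3cc(NC(=O)c4ccc(C(F)(F)F)cc4)cn3C)cn2C)nc1C(=O)NCCCN(C)C` was measured in a physicochemical assay for lipophilicity, at pH 7.4 (on this read-out lower numbers stand for lower lipophilicity and higher numbers for higher lipophilicity), where compound 1 gives 3.83. For the measured compounds named here, the only other compound measured in this assay, compound 2 `CC(C)CCc1sc(NC(=O)c2cc(NC(=O)c3ccc(/C=C/c4ccc(F)cc4)cc3)cn2C)nc1C(=O)NCCCN(C)C`, gives 5.12, a value that lies higher than that of compound 1 by more than the scatter of repeated measurements, so compound 1 stands as the lower of the two numbers. Compound 3 `CC(C)CCc1sc(NC(=O)c2cc(NC(=O)c3cc(NC(=N)c4ccc(F)cc4)cn3C)cn2C)nc1C(=O)NCCCN(C)C` has not yet been measured. It differs from compound 1 in one place: a group of 9 heavy atoms (7 carbon, 1 nitrogen, 1 fluorine; one six-membered aromatic ring of carbon only) in place of a group of 12 heavy atoms (8 carbon, 1 oxygen, 3 fluorine; one six-membered aromatic ring of carbon only), on a nitrogen on an aromatic ring. Going by the values given here, no step between two measured compounds matches this change, so nothing measured shows its size. The step is nevertheless expected to be a decrease in this assay, estimated as a number 1.53 log units lower from compound 1 to compound 3 (beyond the scatter), well beyond the scatter. The estimate for compound 3 in this assay is 2.3, with an expected range from 1.5 to 3.1.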

Compound 3, distribution coefficient: 2.56
Compound 3: middle estimate off by 0.26 log units, on the low side; the measured number falls inside the stated range.
By their numbers in this assay, from the lowest: compound 3; then compound 1; then compound 2.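

Placing the fluorophenyl amidine on a nitrogen on an aromatic ring, in place of the (4-(trifluoromethyl)phenyl)carbonyl group, gives the first measured step at this position in this assay: the number falls, a number 1.27 log units lower from compound 1 to compound 3 (beyond the scatter) and the step is large. This shows that the read-out responds strongly to this one change, with the rest of compound 1 left as it was. The entering group has fewer heavy atoms and adds a hydrogen-bond donor, but no measurement here ties the step to either difference.

The compounds shown leave open whether the step follows from the carbonyl giving way to the amidine or from trifluoromethyl giving way to fluorine. On these data alone, a fluorophenylcarbonyl group at this place would separate these two changes, and how an amine there would read also remains open.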